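Swapping the anilino end of compound 1 for a pyrrolidine amide

This account rests on a few compounds, and the source may have more. Where it says the series, first, only, none or still open, it means among the compounds named here.

Compound 1 `Cc1cc(C(=O)N2CCCCc3ccccc32)ccc1CNC(=O)Nc1ccccc1` sits in the middle of three measured compounds: in a functional assay on HEK293 cells for agonist activity at Vasopressin V2 receptor (Homo sapiens), read by a luciferase reporter and cAMP accumulation (a lower number here means that less compound is needed, a higher number that more compound is needed for the effect), compound 1 gives 130 nM, compound 2 `COC(=O)CNC(=O)NCc1ccc(C(=O)N2CCCCc3ccccc32)cc1C` gives 37 nM, and compound 3 `Cc1cc(C(=O)N2CCCCc3ccccc32)ccc1CNC(=O)N1CCC[C@H]1C(=O)OC(C)(C)C` gives 390 nM. The steps around it are modest: a 3.5-fold lower number from compound 1 to compound 2 (0.55 log units; beyond the scatter) and a 3.0-fold higher number from compound 1 to compound 3 (0.48 log units; beyond the scatter).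

Compound 4 `Cc1cc(C(=O)N2CCCCc3ccccc32)ccc1CNC(=O)N1CCC[C@@H]1C(=O)N(C)C` carries the change (2-(dimethylcarbamoyl)pyrrolidin-1-yl in place of anilino on a carbonyl carbon). The nearest guide is the step from compound 1 to compound 3, where 2-(tert-butoxycarbonyl)pyrrolidin-1-yl replaced anilino on the same carbonyl carbon and the number rose, a 3.0-fold higher number from compound 1 to compound 3 (0.48 log units; beyond the scatter). Within the data shown here, compound 4 keeps the pyrrolidine but ends in a dimethylcarbamoyl group; no measured pair shows that particular exchange, so its own contribution is unknown. Compound 4 is therefore expected to follow compound 3 and give a modestly higher number than compound 1, a 2.3-fold higher number from compound 1 to compound 4 (0.36 log units; beyond the scatter). The estimate for compound 4 in this assay is 300 nM, within a range from 100 nM to 900 nM.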

Compound 4, half-maximal effective concentration: 380 nM
Compound 4: the middle estimate sits 1.3-fold (0.10 log units) below what was measured, within the range that was stated.
By their numbers in this assay, from the lowest: compound 2; then compound 1; then compounds 4 and 3 (each within the scatter of the next).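

In this assay, the step to compound 4 shows that a second pyrrolidine group on this carbonyl carbon also moves the number upward from the anilino compound, a 2.9-fold higher number from compound 1 to compound 4 (0.47 log units; beyond the scatter). The group carried on the pyrrolidine makes no readable difference in this pair, a 1.0-fold lower number from compound 3 to compound 4 (0.01 log units; within the scatter), so 2-(dimethylcarbamoyl)pyrrolidin-1-yl and 2-(tert-butoxycarbonyl)pyrrolidin-1-yl cannot be told apart here, although their stereocentres are drawn in opposite senses. The large step of a 10-fold higher number from compound 2 to compound 4 (1.01 log units; beyond the scatter) shows that compound 4, like compound 3, stands well apart from the open-chain ((methoxycarbonyl)methyl)amino compound.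

Nothing at hand explains these shifts. The compounds shown leave open whether a pyrrolidine bearing a free carboxylic acid, or an unsubstituted pyrrolidine, would stay at this level, and how far each stereocentre matters on its own.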